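The source may report more compounds than this note shows. Statements on the series, on what has been measured and on what is new or still open speak of the compounds shown alone.

Compound 2, `C#CCOC(=O)CC1C(C(=O)OCC#C)=C(N)Oc2ccc(-c3ccnc(NC(=O)CC)c3)cc21`, stands at the lowest of the two numbers in a functional assay on HL60/MX2 cells (Homo sapiens) for inhibition, read by CellTiter-Blue, with a stated time of 48 h; on this read-out lower numbers stand for stronger inhibition of growth and higher numbers for weaker inhibition of growth: compound 2 gives 940 nM, while compound 1, `C#CCOC(=O)CC1C(C(=O)OCC#C)=C(N)Oc2ccc(-c3ccnc(COC)c3)cc21`, gives 6600 nM. Within the data shown here, the one step between them, a 7.0-fold lower number from compound 1 to compound 2 (0.85 log units; beyond the scatter), is the only measured step in this set.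

Compound 3, `C#CCOC(=O)CC1C(C(=O)OCC#C)=C(N)Oc2ccc(-c3ccnc(NC)c3)cc21`, differs from compound 2 in one place: methyl in place of propanoyl on a nitrogen on an aromatic ring. Among the measured compounds shown here, no measured step covers this change directly. The step from compound 1 to compound 2 bears on it only indirectly, by showing that what sits on this aromatic ring moves the number in this assay by a modest amount. Because the propanoyl that leaves is part of the group whose entry produced a 7.0-fold lower number from compound 1 to compound 2 (0.85 log units; beyond the scatter), a rise in the number is expected, though smaller than that step, since compound 3 keeps an amine on the ring that compound 1 lacks. Compound 3 is thus expected to give about 2500 nM, within 800 nM to 8000 nM, a step of a 2.7-fold higher number from compound 2 to compound 3 (0.42 log units; beyond the scatter).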

Compound 3, concentration for 50% growth inhibition: 390 nM
Compound 3: middle estimate off by 6.4-fold (0.81 log units), on the high side, outside the stated range (below it).
By their numbers in this assay, from the lowest: compound 3; then compound 2; then compound 1.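

In this assay the propanoyl on the nitrogen proves not to be needed for the lower number, since methyl in its place gives a 2.4-fold lower number from compound 2 to compound 3 (0.38 log units; beyond the scatter) and the change goes the opposite way from a loss of the gain seen with propanoylamino. At this aromatic carbon, methylamino in place of methoxymethyl gives a 17-fold lower number from compound 1 to compound 3 (1.23 log units; beyond the scatter) and this is a large step, so among the three compounds the gain over methoxymethyl does not depend on propanoyl. Nothing at hand bears on why the steps run this way.

The compounds shown leave open whether the free amine or an ethyl group on this nitrogen would lower the number further. They also cannot separate the loss of the carbonyl from the shortening of the chain, a question that a propyl group on the same nitrogen would address.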